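The source may report more compounds than this note shows. Statements on the series, on what has been measured and on what is new or still open speak of the compounds shown alone.

Of the compounds shown here, three have been measured in an assay for inhibition of Indoleamine 2,3-dioxygenase 1 (Homo sapiens), with stated times of 10 min and 60 min, tested at 10 uM (a lower number here means a weaker effect, a higher number a stronger effect of the compound at the concentration tested), so far. Compound 1 `O=[N+]([O-])c1cccc(CNc2cc(Br)cc3[nH]ncc23)c1` gives 72%, compound 2 `O=[N+]([O-])c1cccc(CNc2cc(C(F)(F)F)cc3[nH]ncc23)c1` gives 45%, and compound 3 `O=[N+]([O-])c1ccccc1CNc1cccc2[nH]ncc12` gives 25%. Among these, compound 2 stands second highest: compound 3 lies closest to it with a lower number, beyond the scatter, and compound 1 lies furthest with a higher number, also beyond the scatter. Among the measured compounds shown here, the one single-point step recorded is a number 27 percentage points lower from compound 1 to compound 2 (beyond the scatter), a modest change beyond the scatter.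

Compound 4 `O=C(O)c1cccc(CNc2cc(C(F)(F)F)cc3[nH]ncc23)c1` is the next candidate for this assay. Relative to compound 2 it differs as follows: carboxy in place of nitro on an aromatic carbon. For the measured compounds named here, no measured pair changes the group on the six-membered ring of carbon only while holding the rest of the structure fixed, so nothing measured bears directly on this step. Compound 3 carries the nitro group at a different place and also lacks the trifluoromethyl group, which is two changes rather than one, so its value can only be noted, not used as a step. Going by the values given here, with no guiding precedent, the replacement of nitro by carboxy is expected to lower the inhibition, and the estimate for compound 4 is 25% with a range of 5% to 50%, which means an expected step of a number 20 percentage points lower from compound 2 to compound 4 (beyond the scatter).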

Compound 4, a percentage reported as inhibition, at one concentration (the size of the read-out at that concentration, not a potency): 11%
Compound 4: the middle estimate sits 14 percentage points above what was measured, within the range that was stated.
By their numbers in this assay, from the lowest: compound 4; then compound 3; then compound 2; then compound 1.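

Among the compounds shown here, with the trifluoromethyl group and the rest of the structure held fixed, carboxy in place of nitro on this aromatic carbon gives a number 34 percentage points lower from compound 2 to compound 4 (beyond the scatter) in this assay and so provides the first single-change reading at this position. It shows that the position is not indifferent to the group it carries: nitro and carboxy have the same count of heavy atoms and no net charge, yet they are not interchangeable here, and the hydrogen-bond count is where the two differ, with carboxy bringing a donor that nitro lacks. Nothing available explains why the inhibition falls with this change.

On these data alone, it remains open whether the loss is specific to carboxy, since a methyl ester, a primary amide, a nitrile or an amine on the same carbon would show how far other groups keep or lose the inhibition seen with nitro. As far as these compounds go, it also remains open whether the same exchange would cost as much with bromo in place of trifluoromethyl, as in compound 1, or with the group at another place on that ring.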